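Acylsulfonamide aryl swap on the difluoromethoxy biphenyl ether

The source may report more compounds than this note shows. Statements on the series, on what has been measured and on what is new or still open speak of the compounds shown alone.

Measured in an assay on cells for displacement of a labelled ligand from prostaglandin E2 receptor EP4 subtype (Homo sapiens), read by scintillation counting; a higher number here means a weaker inhibitor, a lower number a stronger inhibitor:
- compound 1 `Cc1oc(C(=O)NS(=O)(=O)c2ccccc2)cc1COc1ccc(-c2ccccc2)cc1`: 25 nM
- compound 2 `Cc1oc(C(=O)NS(=O)(=O)c2ccccc2)cc1COc1ccc(-c2ccc(OC(F)F)cc2)cc1`: 1.3 nM

Among the measured compounds shown here, compound 2 holds the lower of the two numbers; the only comparison is a 19-fold lower number from compound 1 to compound 2 (1.28 log units; beyond the scatter), and that step changed the biphenyl end, not the sulfonyl end. Compound 3 `Cc1noc(C)c1S(=O)(=O)NC(=O)c1cc(COc2ccc(-c3ccc(OC(F)F)cc3)cc2)c(C)o1` differs from compound 2 by 3,5-dimethyl-1,2-oxazol-4-yl in place of phenyl on a sulfonyl sulfur. For the measured compounds named here, no measured step touches the sulfonyl side, so nothing here sizes this change. The expectation for compound 3 is therefore anchored on compound 2 and its 1.3 nM, with a step of a 1.5-fold higher number from compound 2 to compound 3 (0.19 log units; within the scatter) not expected to reach beyond the scatter, though the range is kept wide. Compound 3 is estimated at 2 nM in this assay, between 0.5 nM and 8 nM.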

Compound 3, inhibition constant in the prostaglandin E2 receptor EP4 subtype assay: 0.6 nM
The estimate for compound 3 lay 3.3-fold (0.52 log units) above the measured number; low and high end bracket the measured number.
By their numbers in the prostaglandin E2 receptor EP4 subtype assay, from the lowest: compound 3; then compound 2; then compound 1.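

Among the compounds shown here, in the prostaglandin E2 receptor EP4 subtype assay, the first change on the sulfonyl side gives a 2.2-fold lower number from compound 2 to compound 3 (0.34 log units; beyond the scatter): at this sulfonyl sulfur, 3,5-dimethyl-1,2-oxazol-4-yl is accepted in place of phenyl, and the number falls further. In a physicochemical assay for solubility, in phosphate buffer, with a stated time of 24 h, at pH 7.4 (on this read-out higher numbers stand for higher solubility and lower numbers for lower solubility), compound 2 gives < 0.6 ug/mL, which is a limit of the assay. In the physicochemical assay compound 3 gives < 0.6 ug/mL, which is also a limit of the assay. In the physicochemical assay the same change cannot be read, with both compounds at a limit of the assay: the limit of < 0.6 ug/mL in the physicochemical assay, at which 2 of the 2 values shown sit.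

The step changes the ring and adds the two methyl groups together, so their shares in the prostaglandin E2 receptor EP4 subtype assay stay apart from view. Also open, going by these compounds, is whether an amine or a carboxylic acid on the group at this sulfonyl sulfur would keep that number and give a readable value in the physicochemical assay.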